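This account rests on a few compounds, and the source may have more. Where it says the series, first, only, none or still open, it means among the compounds named here.

Measured so far:
compound 1 `CC(C)c1ccccc1NC(=O)N[C@@H](C)c1ccccc1` — 96%
compound 2 `COc1ccccc1NC(=O)N[C@H](C)c1ccccc1` — 105%

In an ADME assay on the whole organism with Oryza sativa as the target, tested at 1 uM (a lower number here means a stronger effect, a higher number a weaker effect of the compound at the concentration tested), compound 1 gives 96%. In this assay compound 2 gives 105%. Compound 2 shows the larger of the two numbers, yet the gap to compound 1 falls within the usual scatter, so the two compounds cannot be told apart on these data; both leave the read-out essentially untouched at the concentration tested.

Compound 3 `COc1ccccc1NC(=O)N[C@@H](C)c1ccccc1` is the next compound to be measured. How it differs from compound 2: the two compounds have the same atoms and bonds and differ only in configuration as drawn: 1 of 1 stereo elements differ; a stereocentre at a saturated chain carbon is drawn R in compound 2 and S in compound 3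

For the measured compounds named here, no step between measured compounds is available, so nothing here tells how configuration at this stereocentre matters. Since compound 1 and compound 2, which already differ in the drawn configuration among other things, give values within the scatter of each other, no step beyond the scatter is expected in this assay from compound 2 to compound 3, that is a number 5 percentage points lower from compound 2 to compound 3 (within the scatter). Compound 3 is therefore estimated at 100%, in the range 86% to 114%.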

Compound 3, a percentage reported as activity, at one concentration (the size of the read-out at that concentration, not a potency): 99%
Estimate against measurement, compound 3: 1 percentage points above; the range from low to high includes it.
By their numbers in this assay, from the lowest: compounds 1, 3 and 2 (each within the scatter of the next).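

In this assay, the change from R to S at the stereocentre on the saturated chain carbon comes with a number 6 percentage points lower from compound 2 to compound 3 (within the scatter), so the drawn configuration at this carbon makes no readable difference with methoxy on the aromatic carbon. With the configuration held the same, methoxy in place of isopropyl on an aromatic carbon comes with a number 3 percentage points higher from compound 1 to compound 3 (within the scatter), so this exchange cannot be told from no change either. The first of these readings is a clean one, resting on a single fact: the fact that compounds 2 and 3 differ only in the configuration as drawn

As far as these compounds go, it remains open whether any change to these compounds moves the read-out, since neither step leaves the scatter. From the compounds shown here alone, it is also open how an amine or a carboxylic acid on that aromatic carbon, in place of methoxy or isopropyl, would behave.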